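Swapping a Morpholine Amide for a Methylamide

The source may hold more compounds than are shown below. What is called first, only, known or untested is meant among the compounds shown, and "the series" means these compounds.

Of the compounds shown here, three have been measured in an assay on a protein complex for inhibition of CDK8/Cyclin C (Homo sapiens), with a stated time of 1 h, tested at 10 uM; on this read-out lower numbers stand for less inhibition and higher numbers for more inhibition at the one concentration tested (going by the name of the read-out). Compound 1 `O=C(/C=C/c1ccncc1-c1ccc2ncccc2c1)N1CCOCC1` gives 80% in this assay. Compound 2 `Cn1ncc2cc(-c3cnccc3/C=C/C(=O)N3CCOCC3)ccc21` gives 95%, and compound 3 `CNC(=O)/C=C/c1ccncc1-c1ccc2c(cnn2C)c1` gives 98%. Compound 1 thus stands lowest of the three, beyond the scatter from both others.

Compound 2 and compound 3 share a core and differ only at the amide: methylamino in place of morpholin-4-yl on a carbonyl carbon. This step is a number 3 percentage points higher from compound 2 to compound 3 (within the scatter), so within the scatter the two numbers cannot be told apart. Compound 1 and compound 2 carry different cores; the difference between the two cores is not broken down here, and only their two values can be compared.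

The unmeasured compound 4 `CNC(=O)/C=C/c1ccncc1-c1ccc2ncccc2c1` carries the core of compound 1 and the amide of compound 3. From compound 1 to compound 4 the change is methylamino in place of morpholin-4-yl on a carbonyl carbon, the same change, at the same place, as that from compound 2 to compound 3.

Because a number 3 percentage points higher from compound 2 to compound 3 (within the scatter) lies within the scatter on the core of compound 2, the expectation is that the same change leaves the number of compound 1 nearly unchanged, and the estimated step is a number 3 percentage points higher from compound 1 to compound 4 (within the scatter). Compound 4 is therefore estimated at 83% in this assay, with a range from 70% to 95% expected to cover most repeats.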

Compound 4, a percentage reported as inhibition, at one concentration (the size of the read-out at that concentration, not a potency): 97%
Compound 4: the middle estimate sits 14 percentage points below what was measured; the whole stated range lies below it.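

In this assay, methylamino in place of morpholin-4-yl on the carbonyl carbon gives a number 17 percentage points higher from compound 1 to compound 4 (beyond the scatter) on the core of compound 1, so on this core the swap moves the number by more than repeat measurements would. Set beside the same swap on the other core, this step cannot be told apart from the earlier one, even though only one of the two clears the scatter on its own: the same change on two cores in this assay, a number 3 percentage points higher (within the scatter) from compound 2 to compound 3 and a number 17 percentage points higher (beyond the scatter) from compound 1 to compound 4, 14 percentage points apart, within the scatter of two such steps. This shows that the change can be carried between these two cores without any sign of a loss in this read-out, but two cores are too few to show that the step has a fixed size or that its size depends on the core, and each number is a percentage at one concentration, not a potency.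

The compounds shown leave open how other groups on the same carbonyl carbon would read, for example ethylamino, dimethylamino, or a plain unsubstituted amino group. They also leave open whether the morpholin-4-yl and methylamino pairs would still sit as close together, or as far apart, if the effect were read at other concentrations.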